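Aryl amide variation in a Rho kinase inhibitor series

This account rests on a few compounds, and the source may have more. Where it says the series, first, only, none or still open, it means among the compounds named here.

Measured compounds:
compound 1 `CC(=O)c1ccc(OCC(=O)Nc2cccc(NC(=O)c3ccc(N(C)C)cc3)c2)cc1F`: 445 nM
compound 2 `CCc1ccc(C(=O)Nc2cccc(NC(=O)COc3ccc4c(=O)ccoc4c3)c2)cc1`: 235 nM

In an assay on isolated protein for inhibition of Rho-associated protein kinase 1 (Homo sapiens), read by scintillation counting, radiometric assay and 33P incorporation, with a stated time of 40 min, in the presence of a further agent that is not named here (on this read-out lower numbers stand for stronger inhibition and higher numbers for weaker inhibition), compound 2 gives the lowest of the two numbers, but compound 1 gives a number within the scatter of it, so the two cannot be ordered. Compound 3 `COC(=O)c1ccc(C(=O)Nc2cccc(NC(=O)COc3ccc4c(=O)ccoc4c3)c2)cc1` is not yet measured. It differs from compound 2 in one place: methoxycarbonyl in place of ethyl on an aromatic carbon. The two measured compounds do not share a single-point change, so nothing here tells how this assay responds to replacing ethyl with methoxycarbonyl on an aromatic carbon. The step from compound 2 to compound 3 is therefore expected to stay within the scatter, with no direction preferred; the expected step is a 1.5-fold higher number from compound 2 to compound 3 (0.17 log units; within the scatter). Compound 3 is expected to give 350 nM in this assay, with a range from 120 nM to 1000 nM.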

Compound 3, half-maximal inhibitory concentration: 72 nM
Compound 3: middle estimate off by 4.9-fold (0.69 log units), on the high side, outside the stated range (below it).
By their numbers in this assay, from the lowest: compound 3; then compounds 2 and 1 (each within the scatter of the next).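

In this assay, the aromatic carbon para to a large group proves sensitive to its substituent: methoxycarbonyl in place of ethyl gives a 3.3-fold lower number from compound 2 to compound 3 (0.51 log units; beyond the scatter) and lies beyond the scatter, which the earlier pair, sharing no single-point change, could not show. Methoxycarbonyl is the larger of the two groups and carries hydrogen-bond acceptors where ethyl has none, so on this one pair the position accepts both features without any loss. No measurement available here accounts for the gain or assigns it to either feature.

Going by these compounds, whether a carboxylic acid, a primary amide or a nitrile at this position would follow methoxycarbonyl remains open, as does the effect of a longer ester such as ethoxycarbonyl. Also open, on these data alone, is whether the same change would carry over to the core of compound 1.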